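This account rests on a few compounds, and the source may have more. Where it says the series, first, only, none or still open, it means among the compounds named here.

Series notes, two compounds measured so far. In an assay for binding affinity to Alpha-1A adrenergic receptor (Homo sapiens), read by radioligand binding (a higher number here means a weaker inhibitor, a lower number a stronger inhibitor), compound 1 `COc1ccc(SC)c(NCC2=NCCN2)c1` gives 174 nM and compound 2 `Cc1ccc(S(C)(=O)=O)c(NCC2=NCCN2)c1` gives 776 nM. Compound 2 stands at the higher of the two numbers; the gap to compound 1 is beyond the scatter, so on these two values compound 2 is the weaker binder, and compound 1 the stronger. Within the data shown here, the two structures differ in more than one place, so no single step between them is counted.

Compound 3 `COc1ccc(S(C)(=O)=O)c(NCC2=NCCN2)c1` is not yet measured. Against compound 2 the change is methoxy in place of methyl on an aromatic carbon, on the aromatic carbon meta to the group of 7 heavy atoms and para to the methylsulfonyl group. Compound 1 also carries methoxy at this position and gives the lower number, but it differs from compound 3 elsewhere, so that comparison is only suggestive. The expectation for this assay is a small step down in the number, possibly within the scatter; in this assay compound 3 is estimated at 450 nM, with a range of 150 nM to 1300 nM, which as an expected step means a 1.7-fold lower number from compound 2 to compound 3 (0.24 log units; within the scatter).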

Compound 3, inhibition constant: 1620 nM
For compound 3 the middle estimate is 3.6-fold (0.56 log units) below the measured one; measured number outside the range, above it.
By their numbers in this assay, from the lowest: compound 1; then compound 2; then compound 3.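

With the methylsulfonyl group held in place, this assay gives a 2.1-fold higher number from compound 2 to compound 3 (0.32 log units; beyond the scatter) for methoxy in place of methyl on the aromatic carbon para to that group, so this change does not lower the number and methyl is the better of the two groups here, by a modest step beyond the scatter. With methoxy held in place, methylsulfonyl in place of methylsulfanyl gives a 9.3-fold higher number from compound 1 to compound 3 (0.97 log units; beyond the scatter) in this assay, which ties the lower number of compound 1 to its methylsulfanyl group and not to its methoxy group, a link the earlier pair could not show because its members differ in more than one place. Among these compounds, nothing measured so far offers an explanation for either step.

Still open, on these data alone, is whether methyl would also beat methoxy with methylsulfanyl in place of methylsulfonyl, and so whether the two changes act independently of each other on the shared core. Also open, as far as these compounds go, is how an ethyl, a chlorine or an amine would fare on the aromatic carbon para to the methylsulfonyl group.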